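A few compounds are considered here, and "the series" means these few. Any claim that something is new, unique, unknown or untested is made for them only; others in the source may bear on it.

Compound 1: `COc1ccc(C2C(C#N)=C(N)N(c3cc(OC)c(OC)c(OC)c3)C3=C2C(=O)CC(C)(C)C3)cc1` — in a functional assay on Ehrlich cells (Mus musculus) for cytotoxicity (a higher number here means a weaker inhibitor, a lower number a stronger inhibitor), compound 1 is recorded as "not active" (no number reported), with no number given.
Compound 2: `COc1cc(N2C(N)=C(C#N)C(c3c(O)ccc4ccccc34)C3=C2CC(C)(C)CC3=O)cc(OC)c1OC` — 143000 nM.

Both measured compounds share the same core and differ from each other in more than one place, so their values are simply set side by side. Compound 1 stands without a single number: in this assay it was reported only as not active. Compound 2 does carry a number, and in this assay compound 2 gives 143000 nM, a concentration so high that it counts as a very weak inhibitor. Taken together, the two results suggest that this core gives weak or no inhibition here.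

The unmeasured compound 3 is `COc1cc(N2C(N)=C(C#N)C(c3ccc(C)o3)C3=C2CC(C)(C)CC3=O)cc(OC)c1OC`. It arises from compound 1 by one change: 5-methylfuran-2-yl in place of 4-methoxyphenyl on a saturated ring carbon. Compound 1 has no number. Going by the values given here, no step can be computed, and nothing measured shows what this swap does. The two known results point to weak activity at best, so compound 3 is expected to land in the same weak region, if a number is obtained at all. Compound 3 is expected to give about 150000 nM in this assay, within a range from 40000 nM to 600000 nM.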

Compound 3, half-maximal inhibitory concentration: 216000 nM
Compound 3: middle estimate off by 1.4-fold (0.16 log units), on the low side, within the range that was stated.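

In this assay, replacing 2-hydroxynaphthalen-1-yl with 5-methylfuran-2-yl on the saturated ring carbon gives a 1.5-fold higher number from compound 2 to compound 3 (0.18 log units; within the scatter), a difference no larger than repeat measurements can show, so the two groups cannot be told apart here even though one is a larger fused ring system and the other a single five-membered ring. Going by these compounds, compound 3 gives a measurable value of 216000 nM in this test, whereas compound 1, which carries 4-methoxyphenyl on the same carbon, is recorded as "not active" (no number reported); with no number for compound 1, the step from it to compound 3 cannot be read and its size stays unknown. No measurement shown here explains why these groups give the results they do.

On these data alone, it remains open whether a quite different group on this carbon, such as a carboxylic acid, an amine or a longer alkyl chain, would bring the number in this assay far down. All three compounds also keep the 3,4,5-trimethoxyphenyl group, so what replacing it with an unsubstituted phenyl would do is likewise unanswered.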